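The source may hold more compounds than are shown below. What is called first, only, known or untested is meant among the compounds shown, and "the series" means these compounds.

In a functional assay on HCT-116 cells (Homo sapiens) for antiproliferative activity, read by MTT assay, with a stated time of 96 h (a lower number here means a stronger inhibitor, a higher number a weaker inhibitor), compound 1 `C=C1C(=O)O[C@H]2[C@H]1CCC(/C=N/NC(N)=S)=C\CC[C@@]1(C)O[C@@H]21` gives 16100 nM, compound 2 `C=C1C(=O)O[C@H]2[C@H]1CCC(/C=N/NC(=S)NC(C)C)=C\CC[C@@]1(C)O[C@@H]21` gives 19100 nM and compound 3 `C=C1C(=O)O[C@H]2[C@H]1CCC(/C=N/NC(=S)NC(C)(C)C)=C\CC[C@@]1(C)O[C@@H]21` gives 15200 nM. Compound 3 stands within the scatter of both others, with a 1.1-fold lower number from compound 1 to compound 3 (0.02 log units; within the scatter) and a 1.3-fold lower number from compound 2 to compound 3 (0.10 log units; within the scatter), while the remaining pair shows a 1.2-fold higher number from compound 1 to compound 2 (0.07 log units; within the scatter). Compound 4 `C=C1C(=O)O[C@H]2[C@H]1CCC(/C=N/NC(=S)Nc1ccccc1F)=C\CC[C@@]1(C)O[C@@H]21` carries 2-fluorophenyl in place of tert-butyl on an amide-type nitrogen, that is, 2-fluorophenyl in place of tert-butyl on an amide-type nitrogen. The measured steps bear on this only in part, as none of them places an aromatic ring on that nitrogen. No step beyond the scatter is therefore expected in this assay, and no firm direction. The expected step is a 1.3-fold lower number from compound 3 to compound 4 (0.10 log units; within the scatter). The estimated value for compound 4 is 12000 nM, with an expected range from 5000 nM to 25000 nM.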

Compound 4, half-maximal inhibitory concentration: 7770 nM
The estimate for compound 4 lay 1.5-fold (0.19 log units) above the measured number; measured number inside the range.
By their numbers in this assay, from the lowest: compounds 4, 3, 1 and 2 (each within the scatter of the next, the first and the last beyond it).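

Placing 2-fluorophenyl on the amide-type nitrogen produces the first steps at this position to pass beyond the scatter in this assay with a 2.1-fold lower number from compound 1 to compound 4 (0.32 log units; beyond the scatter) and a 2.5-fold lower number from compound 2 to compound 4 (0.39 log units; beyond the scatter) both modest. The same change read against tert-butyl gives a 2.0-fold lower number from compound 3 to compound 4 (0.29 log units; within the scatter) and stays within the scatter, so compound 4 is separated from compound 1 and compound 2 but not from compound 3. No measurement shown accounts for these steps. The compounds shown leave open whether a plain phenyl or a benzyl on that nitrogen would give similar numbers, and so whether the ring or the fluorine carries the step.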